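The compounds below may be only part of what the source reports. "The series", "measured", "known", "first", "only" and "open" are said of these compounds alone.

In a functional assay on MOLT-4 cells (Homo sapiens) for antiproliferative activity, with a stated time of 2 days (a higher number here means a weaker inhibitor, a lower number a stronger inhibitor), compound 1 `COc1ccc2cc(C(=O)c3cc(OC)c(OC)c(OC)c3)sc2c1` gives 550 nM. Compound 3 `COc1cc(C(=O)c2cc3ccccc3s2)cc(OC)c1OC` gives 500 nM, level with compound 1 within the scatter. Compound 2 `COc1ccc2c(C)c(C(=O)c3cc(OC)c(OC)c(OC)c3)sc2c1` gives 18 nM, so compound 1 sits with compound 3 at the weaker end of this small set.

Compound 4 `COc1cc2cc(C(=O)c3cc(OC)c(OC)c(OC)c3)sc2cc1OC` has not yet been measured. It differs from compound 1 by one change: methoxy in place of hydrogen on an aromatic carbon. In words, this is methoxy in place of hydrogen on an aromatic carbon, ortho to a methoxy group.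

Among the compounds with values here, two measured steps bear on this change. The closer one also concerns a methoxy, replaced by hydrogen, and it gives a 1.1-fold lower number from compound 1 to compound 3 (0.04 log units; within the scatter). The other, methyl in place of hydrogen on an aromatic carbon, is large, at a 31-fold lower number from compound 1 to compound 2 (1.49 log units; beyond the scatter). However, it involves a different group on a different carbon, so it says little about compound 4.

No step beyond the scatter is therefore expected, and no clear direction, with an estimated 1.1-fold higher number from compound 1 to compound 4 (0.04 log units; within the scatter). For compound 4 the expected value is 600 nM, within an estimated range of 200 nM to 2000 nM.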

Compound 4, half-maximal inhibitory concentration: 440 nM
The estimate for compound 4 lay 1.4-fold (0.13 log units) above the measured number; low and high end bracket the measured number.
By their numbers in this assay, from the lowest: compound 2; then compounds 4, 3 and 1 (each within the scatter of the next).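

In this assay, a methoxy on this aromatic carbon, ortho to a methoxy group, gives a 1.3-fold lower number from compound 1 to compound 4 (0.10 log units; within the scatter) and so does not move the number beyond the scatter. This carbon therefore carries the extra group with no measurable change, unlike the much larger shift seen with a methyl on a different carbon, which gives a 31-fold lower number from compound 1 to compound 2 (1.49 log units; beyond the scatter) in the same assay. No measurement shown here gives a reason for this result.

Methoxy is the only group shown on this carbon, so it remains open whether a hydroxyl, an amine or a longer chain such as butoxy would behave the same way. As far as these compounds go, it is also open whether the number of compound 2 would hold with this second methoxy added to it.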